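A few compounds are considered here, and "the series" means these few. Any claim that something is new, unique, unknown or untested is made for them only; others in the source may bear on it.

In a functional assay on K562 cells (Homo sapiens) for antiproliferative activity, read by CellTiter-Glo and CCK-8 assay, with a stated time of 72 h (a higher number here means a weaker inhibitor of growth, a lower number a stronger inhibitor of growth), compound 1 (`Cc1ccc(NC(=O)c2cccc(C(F)(F)F)c2)cc1NC(=O)c1cnc(Nc2ccc(C)c([N+](=O)[O-])c2)nc1N(C)C`) gives > 10000 nM, which is a limit of the assay and not a number. Compound 2 (`Cc1ccc(NC(=O)c2cccc(C(F)(F)F)c2)cc1NC(=O)c1cnc(Nc2ccc(C)c([N+](=O)[O-])c2)nc1`) gives 380 nM, with hydrogen in place of dimethylamino on an aromatic carbon. Within the data shown here, this is the only measured step, an at least 26-fold lower number from compound 1 to compound 2 (1.42 log units; beyond the scatter), and it is large. Compound 3 (`Cc1ccc(Nc2ncc(C(=O)Nc3cc(NC(=O)c4cccc(C(F)(F)F)c4)ccc3C)c(N(C)C)n2)cc1N`) keeps the dimethylamino group and differs from compound 1 elsewhere, with amino in place of nitro on an aromatic carbon, ortho to a methyl group: amino in place of nitro on an aromatic carbon. Among the measured compounds shown here, no measured step covers that exchange, so its own size in this assay has no direct precedent. The step to compound 2 speaks only to the group that compound 3 retains, and with an at least 26-fold lower number from compound 1 to compound 2 (1.42 log units; beyond the scatter) tied to that group's removal, no comparable fall in the number is expected here. Compound 3 is therefore expected to stay close to the limit, and the assay may again report only a limit. The expected step is a number no higher from compound 1 to compound 3 (the limit leaves the size open). For compound 3 the estimated value is 10000 nM, with an estimated range from 3000 nM to 30000 nM.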

Compound 3, concentration for 50% growth inhibition: 1210 nM
Estimate against measurement, compound 3: 8.3-fold (0.92 log units) above, outside the stated range (below it).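

In this assay, the change from 4-methyl-3-nitrophenyl to 3-amino-4-methylphenyl gives an at least 8.2-fold lower number from compound 1 to compound 3 (0.91 log units; beyond the scatter), with the dimethylamino group kept in place. The earlier step, an at least 26-fold lower number from compound 1 to compound 2 (1.42 log units; beyond the scatter), spoke only to the dimethylamino group, whereas this one shows that the number also answers to the group on the aromatic carbon ortho to a methyl group, and that a compound retaining dimethylamino need not stay at the limit. Compound 1 stands at a limit and not a number, which leaves the full size of this step open: the limit of > 10000 nM in this assay, at which 1 of the 3 values shown sits.

The compounds shown leave open what amino in place of nitro does in a compound without the dimethylamino group, as compound 2 still carries the nitro group, and so whether the two exchanges would add up. They also leave open whether the amino group itself matters or only the loss of nitro, a question that a hydroxyl, a methylamino or an acetamido group at the same place could help to answer.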